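Amide-nitrogen aryl swap: compound 2 to compound 4

This account rests on a few compounds, and the source may have more. Where it says the series, first, only, none or still open, it means among the compounds named here.

Measured in an ADME assay on Vero cells (Chlorocebus sabaeus) for cytotoxicity; on this read-out lower numbers stand for higher toxicity in this test and higher numbers for lower toxicity in this test:
compound 1 `O=C(Nc1ccccc1)c1cccc2[nH]c(-c3ccncc3)nc12`: 49.8 uM
compound 2 `COc1ccc(-c2nc3c(C(=O)Nc4cnc(Cl)cn4)cccc3[nH]2)cc1OC`: 78.3 uM
compound 3 `COc1ccc(-c2nc3c(C(=O)Nc4cnc(Cl)cn4)cccc3[nH]2)c(OC)c1OC`: 65.2 uM

All three numbers in this assay sit within the scatter of one another, so compound 2 is not set apart from compound 1 or compound 3 on this read-out. Compound 2 and compound 1 differ in more than one place, so their two values are only read side by side.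

The new compound 4 `COc1ccc(-c2nc3c(C(=O)Nc4ncccc4O)cccc3[nH]2)cc1OC` is derived from compound 2 by 3-hydroxypyridin-2-yl in place of 5-chloropyrazin-2-yl on an amide-type nitrogen.

For the measured compounds named here, the only single-site step among the measured compounds is a 1.2-fold lower number from compound 2 to compound 3 (0.08 log units; within the scatter), and it concerns a substituent on an aromatic carbon rather than the group on the amide-type nitrogen, so no measured step addresses the change made here. With the whole series lying flat in this assay and the swap touching a site without precedent, the expectation is no step beyond the scatter, a 1.1-fold lower number from compound 2 to compound 4 (0.05 log units; within the scatter). Compound 4 is therefore estimated at 70 uM, within 30 uM to 150 uM.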

Compound 4, half-maximal toxic concentration: 164 uM
Compound 4: middle estimate off by 2.3-fold (0.37 log units), on the low side; measured number above the stated range.
By their numbers in this assay, from the lowest: compounds 1, 3 and 2 (each within the scatter of the next); then compound 4.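

The group on the amide-type nitrogen is the only site among the compounds shown where a single change moves this assay beyond the scatter, with a 2.1-fold higher number from compound 2 to compound 4 (0.32 log units; beyond the scatter), a modest step towards lower toxicity in this test. The swap removes the chlorine and a ring nitrogen and brings in a hydroxy group with its hydrogen-bond donor, and this single step cannot separate these differences from one another. No measurement shown here explains the step.

On these data alone, whether the step follows the hydroxy group or the ring change remains open, and an unsubstituted pyridin-2-yl or a 3-methoxypyridin-2-yl on the amide-type nitrogen would separate the two. Also open, as far as these compounds go, is whether the same swap would raise the number when made on compound 3.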